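The compounds below may be only part of what the source reports. "The series", "measured", "known", "first", "only" and "open" are said of these compounds alone.

Two numbers exist so far for this series. In a physicochemical assay for solubility, with a stated time of 18 h, at pH 7.4 (a higher number here means a more soluble compound, a lower number a less soluble compound), compound 1 `CC(C)Cc1ccc2c(NCCCNCc3ccco3)ccnc2c1` gives 4200 nM and compound 2 `COc1ccc(Oc2ccc3c(NCCCNCc4cccc(OC)c4O)ccnc3c2)cc1` gives 14500 nM as the higher of the two, a gap beyond the scatter. The next compound to read is compound 3 `COc1cccc(CNCCCNc2ccnc3cc(CC(C)C)ccc23)c1O` and its change from compound 2 is isobutyl in place of 4-methoxyphenoxy on an aromatic carbon in a single place: isobutyl in place of 4-methoxyphenoxy on an aromatic carbon of a six-membered aromatic ring of carbon only, part of a fused or bridged system of two rings. No measured pair isolates this change, so its size has not been shown directly. Compound 1 also bears isobutyl and sits at 4200 nM as the lower number, which gives the only hint of direction, a weak one since it differs from compound 2 in more than that group. A modest fall, near the scatter, is expected: the estimated step is a 1.8-fold lower number from compound 2 to compound 3 (0.26 log units; within the scatter) in this assay with wide uncertainty. For compound 3 the estimated value is 8000 nM with an expected range from 2500 nM to 25000 nM in this read-out.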

Compound 3, solubility: 4200 nM
The estimate for compound 3 lay 1.9-fold (0.28 log units) above the measured number, and the stated range covers the measured number.
By their numbers in this assay, from the lowest: compounds 1 and 3 (each within the scatter of the next); then compound 2.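

In this assay, isobutyl in place of 4-methoxyphenoxy on an aromatic carbon, meta to a fused ring and para to a fused ring, now has a directly measured size: a 3.5-fold lower number from compound 2 to compound 3 (0.54 log units; beyond the scatter). This shows that the read-out responds to the group at this position of the shared core, at least in the setting of the 2-hydroxy-3-methoxyphenyl side chain. Within the data shown here, with isobutyl held fixed, 2-hydroxy-3-methoxyphenyl in place of furan-2-yl on a saturated chain carbon bound to an amine nitrogen gives no change at the digits printed from compound 1 to compound 3 (within the scatter), so of these two single-place changes only the one on the aromatic carbon moves the number beyond the scatter, and nothing available explains either step.

The group that leaves differs from isobutyl in both its aromatic ring and its two oxygen atoms, so the step does not separate these features, and an unsubstituted phenoxy or a simple methoxy group at this carbon would bear on that. Going by these compounds, whether the step holds with furan-2-yl on the chain remains open, as does the effect of an amine or a carboxylic acid at the same carbon.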